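The compounds below may be only part of what the source reports. "The series", "measured", "known", "first", "only" and "open" are said of these compounds alone.

Compound 1 `Cc1cncc(-c2ccc3[nH]c(=O)nc(-c4ccccc4)c3c2)c1`: > 50000 nM
Compound 2 `CN(C)c1ccc(-c2ccc3[nH]c(=O)nc(-c4ccccc4)c3c2)cn1`: 50000 nM
Compound 3 `O=c1nc(-c2ccccc2)c2cc(-c3ccc(N4CCCC4)nc3)ccc2[nH]1`: > 50000 nM

In an ADME assay on L6 cells (Rattus norvegicus) for cytotoxicity, read by fluorescence and resazurin assay, with a stated time of 72 h (on this read-out higher numbers stand for an effect only at larger amounts of compound and lower numbers for an effect already at smaller amounts), compound 1 gives > 50000 nM, which is a limit and not a number. Compound 3 also gives a limit, > 50000 nM. Together they make up (the limit of > 50000 nM in this assay, at which 2 of the 3 values shown sit). Among the compounds with values here, compound 2 gives the only exact number, 50000 nM. Compound 1 therefore has no exact position on this scale.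

The next compound, compound 4 `O=c1nc(-c2ccccc2)c2cc(-c3cn[nH]c3)ccc2[nH]1`, carries 1H-pyrazol-4-yl in place of 5-methylpyridin-3-yl on an aromatic carbon of the core: 1H-pyrazol-4-yl in place of 5-methylpyridin-3-yl on an aromatic carbon. Within the data shown here, no measured compound carries this group, and no measured step covers this exchange. From the compounds shown here alone, the nearest evidence is a number no lower from compound 2 to compound 3 (the limit leaves the size open), a change of pyrrolidin-1-yl for dimethylamino whose size stays open, so it bears on this exchange only loosely.

Among the measured compounds shown here, the expectation rests mainly on compound 2 at 50000 nM, the one exact number. The expected change in this assay is small, with a modest shift to a lower number at most, and it may well not exceed the scatter. The step is estimated as an at least 1.2-fold lower number from compound 1 to compound 4 (0.09 log units; that floor lies within the scatter). For compound 4 the expected value is 40000 nM, with an estimated range of 12000 nM to 100000 nM.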

Compound 4, half-maximal effective concentration: > 50000 nM
Compound 4: only a limit was reported (the forecaster's own chance of this, stated with the estimate: 50%); middle value at least 1.2-fold (0.09 log units) from the limit.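

In this assay compound 4 gives > 50000 nM, which is a limit and not a number. Compound 1 also carries a limit, so no step between compound 1 and compound 4 can be read: the limit of > 50000 nM in this assay, at which 3 of the 4 values shown sit.

The compounds shown leave open how far 1H-pyrazol-4-yl and 5-methylpyridin-3-yl differ in this assay.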